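The compounds below may be only part of what the source reports. "The series", "measured", "known", "first", "only" and "open" are said of these compounds alone.

Compound 1 `COc1cc(C)nc2n/c(=N/C(=O)c3c(-c4ccc(Cl)cc4Cl)noc3C)sn12` gives 30.9% in a functional assay on the whole organism (strain L.) for inhibition, with Echinochloa crus-galli as the target, with a stated time of 72 h, tested at 10 mg/L (on this read-out lower numbers stand for less inhibition of growth and higher numbers for more inhibition of growth at the one concentration tested), the second highest of the three numbers shown. Compound 3 `CSc1cc(C)nc2n/c(=N/C(=O)c3c(-c4ccc(Cl)cc4Cl)noc3C)sn12` gives 37.5%, and the step of a number 6.6 percentage points higher from compound 1 to compound 3 (within the scatter) stays within the scatter. Among the measured compounds shown here, compound 2 `COc1cc(Cl)nc(NC(=S)NC(=O)c2c(-c3ccc(Cl)cc3Cl)noc2C)n1` gives 18.5%, a number below compound 1 beyond the scatter, but no single-place step connects these two compounds. Compound 4 `COc1cc(Cl)nc2n/c(=N/C(=O)c3c(-c4ccc(Cl)cc4Cl)noc3C)sn12` differs from compound 1 by chloro in place of methyl on an aromatic carbon. For the measured compounds named here, none of the measured steps puts chloro in place of methyl on the shared core, so no measured step bears directly on this change, and the one single step known, a number 6.6 percentage points higher from compound 1 to compound 3 (within the scatter), lies itself within the scatter. Compound 4 is therefore expected to show no step beyond the scatter, a number 0.9 percentage points lower from compound 1 to compound 4 (within the scatter). The estimate for compound 4 is 30%, with a range from 14% to 48%.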

Compound 4, percent growth inhibition at one concentration: 10.8%
Estimate against measurement, compound 4: 19.2 percentage points above; measured number outside the range, below it.
By their numbers in this assay, from the lowest: compounds 4 and 2 (each within the scatter of the next); then compounds 1 and 3 (each within the scatter of the next).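

In this assay, chloro in place of methyl gives a number 20.1 percentage points lower from compound 1 to compound 4 (beyond the scatter), the first single-place step shown that lies beyond the scatter. The only earlier such step, at the methoxy group, was a number 6.6 percentage points higher from compound 1 to compound 3 (within the scatter), so this position opposite the ring nitrogen is the first shown to respond to a change. Nothing available explains this drop. Still open, from the compounds shown here alone, is whether an amine or an ethyl group at this position would give a number nearer that of methyl or that of chloro. Also open, going by these compounds, is whether the same change would give a similar step on the core of compound 3.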